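The source may report more compounds than this note shows. Statements on the series, on what has been measured and on what is new or still open speak of the compounds shown alone.

Measured in a functional assay on DU-145 cells (Homo sapiens) for inhibition, read by MTT assay, with a stated time of 72 h; a lower number here means a stronger inhibitor, a higher number a weaker inhibitor:
- Compound 1 `O=C1C=C(N2CCN(c3ccc(F)cc3)CC2)C(=O)c2ccccc21`: 11700 nM
- Compound 2 `O=C1C=C(N2CCN(c3ccc(Br)cc3)CC2)C(=O)c2ccccc21`: > 50000 nM (a limit of the assay, not a number)
- Compound 3 `COc1ccc(N2CCN(C3=CC(=O)c4ccccc4C3=O)CC2)cc1`: 46100 nM

Of the two results that are true numbers, the higher belongs to compound 3 at 46100 nM, so it is the weaker inhibitor of that pair: a 3.9-fold higher number from compound 1 to compound 3 (0.60 log units; beyond the scatter). Compound 2 gives only a limit. Set against that limit, an at least 1.0-fold lower number from compound 2 to compound 3 (0.03 log units; that floor lies within the scatter), so compound 3 and compound 2 cannot be told apart.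

Compound 4 `Cc1ccc(N2CCN(C3=CC(=O)c4ccccc4C3=O)CC2)cc1` carries methyl in place of methoxy on an aromatic carbon, para to a large group: methyl in place of methoxy on an aromatic carbon. Among the measured compounds shown here, no measured step involves methyl, so this change has not been tested directly. The nearest guides are the other swaps on that aromatic carbon. Bromo in place of fluoro gives an at least 4.2-fold higher number from compound 1 to compound 2 (0.63 log units; beyond the scatter), and methoxy in place of fluoro gives a 3.9-fold higher number from compound 1 to compound 3 (0.60 log units; beyond the scatter). Only compound 1 sits clearly lower, so compound 4 is expected to stay near compound 3, perhaps slightly lower. The expected change is a 1.5-fold lower number from compound 3 to compound 4 (0.19 log units; within the scatter), a step not expected to stand clear of the scatter. In this assay the estimate for compound 4 is 30000 nM, expected to fall between 12000 nM and 50000 nM.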

Compound 4, half-maximal inhibitory concentration: 8200 nM
Beside the measured number, compound 4's estimate is 3.7-fold (0.56 log units) above it; the whole stated range lies above it.
By their numbers in this assay, from the lowest: compounds 4 and 1 (each within the scatter of the next); then compound 3. At a limit, above all of these: compound 2.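

In this assay, putting methyl in place of methoxy on this aromatic carbon, para to a large group, gives a 5.6-fold lower number from compound 3 to compound 4 (0.75 log units; beyond the scatter), so a single swap at this position can move the result well past the usual scatter. Fluoro is also no longer alone at the low end of the series: methyl gives a 1.4-fold lower number from compound 1 to compound 4 (0.15 log units; within the scatter), and these two groups cannot be told apart. Methyl also stands clear of bromo, an at least 6.0-fold lower number from compound 2 to compound 4 (0.78 log units; beyond the scatter), although that step rests on a limit of the assay and not on a true number: the limit of > 50000 nM in this assay, at which 1 of the 4 values shown sits.

The compounds shown leave open whether another group on this carbon, such as an amine, a hydroxyl or a longer chain like ethyl, would fall with fluoro and methyl or with methoxy and bromo. They also offer no explanation for this split, since each of the four groups appears only once, at this one position on the shared core.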